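Methylamino in place of methyl on a shared nucleoside core

This account rests on a few compounds, and the source may have more. Where it says the series, first, only, none or still open, it means among the compounds named here.

Compound 1, `C#Cc1cn([C@@H]2O[C@H](CO)[C@@H](O)[C@H]2O)c2ncnc(C)c12`: > 20000 nM, a limit of the assay.
Compound 2, `COc1ncnc2c1c(-c1cccs1)cn2[C@@H]1O[C@H](CO)[C@@H](O)[C@H]1O`: 80 nM.
Compound 3, `Cc1ncnc2c1c(-c1cccs1)cn2[C@@H]1O[C@H](CO)[C@@H](O)[C@H]1O`: > 20000 nM, a limit of the assay.

In a functional assay on HCT-116 cells (Homo sapiens), read by MTT assay, with a stated time of 72 h (on this read-out higher numbers stand for weaker inhibition and lower numbers for stronger inhibition), only compound 2 gives a number. Compound 3 sits at a limit, so its standing among the three can be told only in part: the step of an at least 250-fold higher number from compound 2 to compound 3 (2.39 log units; beyond the scatter) is large, whereas the step that the two limits leave unreadable from compound 1 to compound 3 cannot be read because of the limit of > 20000 nM in this assay, at which 2 of the 3 values shown sit.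

Compound 4, `CNc1ncnc2c1c(-c1cccs1)cn2[C@@H]1O[C@H](CO)[C@@H](O)[C@H]1O`, differs from compound 3 by methylamino in place of methyl on an aromatic carbon. The step that bears on this change is the one from compound 2 to compound 3, in which methoxy gave way to methyl and the number rose by at least the large margin shown. The change to compound 4 again exchanges methyl for a small group carrying a heteroatom, this time methylamino, and an account restricted to these three compounds can do no more than point back to that step.

Compound 4 is therefore expected to fall well below the limit at which compound 3 stands, with an expected step of an at least 660-fold lower number from compound 3 to compound 4 (2.82 log units; beyond the scatter). The estimate for compound 4 is 30 nM, between 5 nM and 300 nM.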

Compound 4, half-maximal inhibitory concentration: > 20000 nM
Compound 4 was reported as a limit; the forecaster's own chance of this, stated with the estimate: 5%; middle value at least 660-fold (2.82 log units) away from the limit.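

In this assay compound 4 gives > 20000 nM, a limit of the assay. Methylamino in place of methoxy on this aromatic carbon gives an at least 250-fold higher number from compound 2 to compound 4 (2.39 log units; beyond the scatter), so methylamino does not reproduce the result of methoxy here, and exchanging methyl for a small group carrying a heteroatom is not enough on its own to bring the number down: among the thiophen-2-yl compounds shown, only compound 2 gives a number. The step between compound 3 and compound 4 cannot be read, any more than the one between compound 1 and compound 3, because both ends of each sit at the same limit: the limit of > 20000 nM in this assay, at which 3 of the 4 values shown sit.

As far as these compounds go, how far compound 3 and compound 4 lie past that limit remains open, and so does whether methyl and methylamino differ at all in this assay. Also open, from the compounds shown here alone, is whether the low number belongs to methoxy alone or extends to a longer ether such as ethoxy, or to other groups at this position on the shared core, such as an unsubstituted amine or dimethylamino.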